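This account rests on a few compounds, and the source may have more. Where it says the series, first, only, none or still open, it means among the compounds named here.

Working notes on the series. In a functional assay on B16 cells (Mus musculus) for antiproliferative activity, with a stated time of 72 h (a lower number here means a stronger inhibitor, a higher number a weaker inhibitor), compound 1 `OC[C@H]1O[C@@H](n2cnc3c(NCc4ccccc4Br)ncnc32)[C@H](O)[C@@H]1O` gives only a limit, > 166000 nM. Compound 2 `COc1ccc(CNc2ncnc3c2ncn3[C@@H]2O[C@H](CO)[C@@H](O)[C@H]2O)c(OC)c1` carries 2,4-dimethoxyphenyl on a saturated chain carbon bound to a nitrogen on an aromatic ring; in this assay compound 2 reports "not determined" (no result reported), so no number stands for it. Where compound 2 stands can be placed only against the single other value shown in this assay: the limit of > 166000 nM in this assay, at which 1 of the 2 values shown sits. Compound 3 `Cc1cccc(CNc2ncnc3c2ncn3[C@@H]2O[C@H](CO)[C@@H](O)[C@H]2O)c1O` differs from compound 2 by 2-hydroxy-3-methylphenyl in place of 2,4-dimethoxyphenyl on a saturated chain carbon bound to a nitrogen on an aromatic ring. Going by the values given here, no measured pair differs in one place, so no size of step can be read from the data. The change from compound 2 to compound 3 is expected to leave the result in this assay within the scatter, or without a number at all, because compound 1 gives > 166000 nM. Compound 3 is expected to give 100000 nM in this assay, with a range from 20000 nM to 300000 nM.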

Compound 3, half-maximal inhibitory concentration: > 166000 nM
Compound 3 ended at the assay's limit (the forecaster's own chance of this, stated with the estimate: 60%); middle value at least 1.6-fold (0.22 log units) from the limit.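

Compound 1 and compound 3 both end at a limit in this assay, so the step between them cannot be read, and no new step follows from compound 3: the limit of > 166000 nM in this assay, at which 2 of the 3 values shown sit.

The compounds shown leave open whether any group on a saturated chain carbon bound to a nitrogen on an aromatic ring gives a number rather than a limit in this assay.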